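Swapping a Methyl for a Benzyloxycarbonyl Group

The compounds below may be only part of what the source reports. "The series", "measured", "known", "first", "only" and "open" are said of these compounds alone.

In an ADME assay on HaCaT cells (Homo sapiens) for cytotoxicity, read by MTT assay, with a stated time of 48 h (a higher number here means a weaker inhibitor, a lower number a stronger inhibitor), compound 1 `c1ccc(-c2nn(-c3ccccc3)cc2-c2nc3ccccc3[nH]2)cc1` gives > 50000 nM, a limit of the assay and not a true number. Compound 2 `Cc1ccc2[nH]c(-c3cn(-c4ccccc4)nc3-c3ccccc3)nc2c1` gives > 50000 nM, which is likewise a limit. On these data alone, compound 2 therefore stands at the limit of > 50000 nM in this assay, at which 2 of the 2 values shown sit, and its real value remains unknown.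

Compound 3 `O=C(OCc1ccccc1)c1ccc2[nH]c(-c3cn(-c4ccccc4)nc3-c3ccccc3)nc2c1` carries benzyloxycarbonyl in place of the methyl on an aromatic carbon, a far larger change: benzyloxycarbonyl in place of methyl on an aromatic carbon. Going by the values given here, only one measured step bears on it, a step that the two limits leave unreadable from compound 1 to compound 2, and that step involved methyl in place of hydrogen on an aromatic carbon. It offers no size to carry forward, so the expectation rests mainly on both measured compounds sitting at the limit. The expected outcome is a number no higher from compound 2 to compound 3 (the limit leaves the size open), with no clear direction foreseen. For compound 3 the estimated value is 50000 nM, with an expected range of 20000 nM to 100000 nM.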

Compound 3, half-maximal inhibitory concentration: > 50000 nM
Compound 3: a limit, no number; the forecaster's own chance of this, stated with the estimate: 70%; the middle value lies on the limit itself.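

Compound 3 also gives only a limit, not a true number, so its steps from compound 1 and from compound 2 cannot be read: the limit of > 50000 nM in this assay, at which 3 of the 3 values shown sit.

On these data alone, the real values of all three compounds in this assay stay open, as does whether methyl or benzyloxycarbonyl changes them at all.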